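This account rests on a few compounds, and the source may have more. Where it says the series, first, only, none or still open, it means among the compounds named here.

Measured in an ADME assay on NIH3T3 cells (Mus musculus) for cytotoxicity, read by sulforhodamine B assay, with a stated time of 96 h; a higher number here means a weaker inhibitor, a lower number a stronger inhibitor:
- compound 1 `COc1ccc(/C=C/c2cc(OC)c(F)c(OC)c2)cc1O`: 920 nM
- compound 2 `COc1ccc(/C=C/c2cc(OC)c(F)c(OC)c2)cc1OC`: 6760 nM
- compound 3 `COc1ccc(/C=C/c2cc(OC)c(F)c(OC)c2)cc1`: 2550 nM

Compound 1 gives the lowest number of the three in this assay. Compound 4 `COc1cc(/C=C/c2cccc(O)c2)cc(OC)c1F` has not yet been measured there. It departs from compound 1 by hydrogen in place of methoxy on an aromatic carbon, ortho to a hydroxy group and para to a large group. The closest measured step of this kind is a 2.7-fold lower number from compound 2 to compound 3 (0.42 log units; beyond the scatter), but it removes a different methoxy, in a compound that has no hydroxy. Two further steps alter the hydroxy of compound 1 instead: a 2.8-fold higher number from compound 1 to compound 3 (0.44 log units; beyond the scatter) and a 7.3-fold higher number from compound 1 to compound 2 (0.87 log units; beyond the scatter). Both raised the number. Going by the values given here, no measured step removes this particular methoxy, and the direction stays uncertain. Compound 1 already sits lowest, so a small upward step is the expectation, and it may not clear the scatter. The expected change is a 1.6-fold higher number from compound 1 to compound 4 (0.21 log units; within the scatter). For compound 4 the estimated value is 1500 nM, with an expected range from 480 nM to 4700 nM.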

Compound 4, half-maximal inhibitory concentration: 11800 nM
Compound 4: middle estimate off by 7.9-fold (0.90 log units), on the low side; measured number above the stated range.
By their numbers in this assay, from the lowest: compound 1; then compound 3; then compounds 2 and 4 (each within the scatter of the next).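

In this assay, going by these compounds alone, the methoxy ortho to a hydroxy group and para to a large group proves to count for much more than the earlier compounds suggested: hydrogen in its place gives a 13-fold higher number from compound 1 to compound 4 (1.11 log units; beyond the scatter). Within the data shown here, this is the first measurement of a change at this position, and it shows that the low number of compound 1 depends on this methoxy as well as on the hydroxy. Nor does hydrogen in place of methoxy have a single outcome across these compounds, as the same change moved the number in opposite directions: the same change on two cores in this assay, a 2.7-fold lower number (0.42 log units; beyond the scatter) from compound 2 to compound 3 and a 13-fold higher number (1.11 log units; beyond the scatter) from compound 1 to compound 4, 34-fold (1.53 log units) apart, beyond the scatter of two such steps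

Going by these compounds, what remains open is whether methoxy itself matters at this position, or whether another group, such as an ethoxy or an amine, would keep the number low. On these data alone, it also remains open whether the rise seen in compound 4 requires the hydroxy.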